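Chain lengthening from compound 3 to compound 4

A few compounds are considered here, and "the series" means these few. Any claim that something is new, unique, unknown or untested is made for them only; others in the source may bear on it.

In a functional assay on DU-145 cells (Homo sapiens) for inhibition, read by MTT assay, with stated times of 18 h and 4 h (a higher number here means a weaker inhibitor, a lower number a stronger inhibitor), compound 1 `CCCCCCCCOP(=O)(O)OCCSC(=S)N1CCCC1` gives 47100 nM. Compound 2 `CCCOP(=O)(O)OCCSC(=S)N1CCCCC1` gives > 100000 nM, which is a limit. Compound 3 `CCCOP(=O)(O)OCCSC(=S)N1CCCC1` gives > 100000 nM, also a limit, and so stands at the limit of > 100000 nM in this assay, at which 2 of the 3 values shown sit. Compound 4 `CCCCCCOP(=O)(O)OCCSC(=S)N1CCCC1` is not yet measured. It differs from compound 3 by propyl in place of hydrogen on a saturated chain carbon, three bonds along the chain from an oxygen on an unsaturated carbon, with propyl in place of hydrogen on a saturated chain carbon. Among the compounds with values here, the one readable step that bears on this is an at least 2.1-fold higher number from compound 1 to compound 3 (0.32 log units; beyond the scatter), with hydrogen in place of pentyl at that same place. Compound 4 restores part of that chain, so some recovery is expected. The step expected in this assay is an at least 1.3-fold lower number from compound 3 to compound 4 (0.12 log units; that floor lies within the scatter), modest and towards a lower number. Compound 4 is estimated at 75000 nM, with an expected range of 42000 nM to 130000 nM.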

Compound 4, half-maximal inhibitory concentration: > 100000 nM
Compound 4: a limit, no number; the forecaster's own chance of this, stated with the estimate: 40%; middle value at least 1.3-fold (0.12 log units) away from the limit.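

In this assay the value of compound 4 is a limit, so propyl to hexyl at this position brings no readable gain; the steps from compound 2 to compound 3 and from compound 3 to compound 4 cannot be read. Hydrogen in place of ethyl, six bonds along the chain from an oxygen on an unsaturated carbon, gives an at least 2.1-fold higher number from compound 1 to compound 4 (0.32 log units; beyond the scatter) and so places the only readable value of the series at the longest chain, in compound 1. Most of the series remains at the limit: the limit of > 100000 nM in this assay, at which 3 of the 4 values shown sit.

Going by these compounds, whether a longer chain than that of compound 1 lowers the number further remains open. So does whether piperidin-1-yl and pyrrolidin-1-yl differ on a chain long enough to give a readable value.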